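A few compounds are considered here, and "the series" means these few. Any claim that something is new, unique, unknown or untested is made for them only; others in the source may bear on it.

The measured compounds:

Compound 1, `O=C(NCc1ccc(F)cc1)c1nc(Br)c2cccnc2c1NCc1ccccc1`, gives in a functional assay on HCT-116 cells (Homo sapiens) for cytotoxicity, read by MTT assay, with a stated time of 72 h (on this read-out higher numbers stand for weaker inhibition and lower numbers for stronger inhibition), a result reported only as a limit of the assay, > 20000 nM.
Compound 2, `N[C@H]1CC[C@H](Nc2c(C(=O)NCc3cccc(C(F)(F)F)c3)nc(Br)c3cccnc23)CC1`, has in this assay the entry "not determined" (no result reported), so no result is reported for it.
Compound 3, `N[C@H]1CC[C@H](Nc2c(C(=O)NCc3ccc(F)cc3)nc(Br)c3cccnc23)CC1`, gives in this assay 7000 nM.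

Compound 3 therefore holds the only number shown in this assay; the one further value is a limit, and the one further entry carries no number. For the measured compounds named here, the single measured step with a number attached is an at least 2.8-fold lower number from compound 1 to compound 3 (0.45 log units; beyond the scatter), in which a 4-aminocyclohexyl group entered on a nitrogen on an aromatic ring.

Compound 4, `O=C(NCc1ccc(F)cc1)c1nc(Br)c2cccnc2c1NCc1ccc(F)cc1`, differs from compound 3 as follows: 4-fluorobenzyl in place of 4-aminocyclohexyl on a nitrogen on an aromatic ring. This undoes the group that entered between compound 1 and compound 3 and puts in its place a 4-fluorobenzyl group, which stands close to the benzyl group of compound 1. Going by the values given here, the only step that bears on the change thus runs in the opposite direction, and the step from compound 3 to compound 4 is expected to run back toward the level of compound 1, whose value sits at the limit of > 20000 nM in this assay, at which 1 of the 3 values shown sits. In this assay compound 4 is expected to give 20000 nM, within 8000 nM to 60000 nM, which would mean an estimated step of a 2.9-fold higher number from compound 3 to compound 4 (0.46 log units; beyond the scatter).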

Compound 4, half-maximal inhibitory concentration: > 20000 nM
Compound 4: no number, only a limit; the forecaster's own chance of this, stated with the estimate: 65%; the middle value sits exactly at the limit.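

Leaving the 4-aminocyclohexyl group for 4-fluorobenzyl on this nitrogen gives an at least 2.8-fold higher number from compound 3 to compound 4 (0.45 log units; beyond the scatter) in this assay, and this mirrors an at least 2.8-fold lower number from compound 1 to compound 3 (0.45 log units; beyond the scatter). The only measured number among the compounds shown therefore stands against two benzyl-type groups on this nitrogen instead of one, so the contrast no longer rests on the plain benzyl group of compound 1 alone. Compound 1 and compound 4 each carry a limit and not a number, so the step with fluoro in place of hydrogen on an aromatic carbon cannot be read, and nothing can be said about the fluoro group from this pair: the limit of > 20000 nM in this assay, at which 2 of the 4 values shown sit.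

From the compounds shown here alone, it remains open whether the amine or the cyclohexyl ring of the 4-aminocyclohexyl group goes with the lower number, a question that a plain cyclohexyl group, a 4-hydroxycyclohexyl group or an open aminobutyl chain on the same nitrogen could separate. The amide side also stays unread, since compound 2, with its trifluoromethyl group on the benzyl amide, has no reported result to set against compound 3.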